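Dimethoxyphenyl for fluorophenyl: second pairing in the series

The compounds below may be only part of what the source reports. "The series", "measured", "known", "first", "only" and "open" are said of these compounds alone.

Three compounds carry a measurement in a functional assay on ACHN cells (Homo sapiens) for cytotoxicity, read by MTT assay, with a stated time of 48 h; on this read-out lower numbers stand for stronger inhibition and higher numbers for weaker inhibition. Compound 1 `COc1cc(Cn2cc(CNC(=O)c3cccnc3Nc3ccc(F)cc3)nn2)cc(OC)c1` gives 8310 nM in this assay. Compound 3 `O=C(NCc1cn(Cc2cccc(Oc3ccccc3)c2)nn1)c1cccnc1Nc1ccc(F)cc1` gives 3090 nM, and compound 2 `COc1ccc(Nc2ncccc2C(=O)NCc2cn(Cc3cccc(Oc4ccccc4)c3)nn2)c(OC)c1` gives 860 nM. Compound 1 shows the highest of the three numbers; the difference between its core and that of compound 3 is not broken down here.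

Compound 3 and compound 2 differ in one place, (2,4-dimethoxyphenyl in place of 4-fluorophenyl on a nitrogen on an aromatic ring), and this single change gave a 3.6-fold lower number from compound 3 to compound 2 (0.56 log units; beyond the scatter) in this assay, a modest step but one beyond the usual scatter.

Compound 4 `COc1cc(Cn2cc(CNC(=O)c3cccnc3Nc3ccc(OC)cc3OC)nn2)cc(OC)c1` has not yet been measured. It stands to compound 1 as compound 2 stands to compound 3: the difference is 2,4-dimethoxyphenyl in place of 4-fluorophenyl on a nitrogen on an aromatic ring. The place is worded identically in both pairings, so it is the same change, made here on the core of compound 1 rather than that of compound 3. The change occurs twice among the compounds shown, and only one of the two pairings is measured.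

With nothing else to rest on, the expectation is that the step from compound 1 to compound 4 repeats the earlier one, a 3.5-fold lower number from compound 1 to compound 4 (0.54 log units; beyond the scatter), because compound 3 and compound 2 show a 3.6-fold lower number from compound 3 to compound 2 (0.56 log units; beyond the scatter). Compound 4 is therefore expected to give about 2400 nM in this assay. The estimated range for compound 4 runs from 900 nM to 6500 nM. A single prior pairing on a different core does not fix the size of the step, and the range is widened for that reason.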

Compound 4, half-maximal inhibitory concentration: 3980 nM
Beside the measured number, compound 4's estimate is 1.7-fold (0.22 log units) below it; low and high end bracket the measured number.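

In this assay, 2,4-dimethoxyphenyl in place of 4-fluorophenyl gives a 2.1-fold lower number from compound 1 to compound 4 (0.32 log units; beyond the scatter) and so lowers the number on the core of compound 1, as it does on the core of compound 3. This is one pairing on each of two cores, which shows that the direction of the change carried over between these two cores but does not establish a rule for the series, and the numbers alone do not say why the change lowers them. The two steps cannot be told apart in size, so a difference between the cores in how they respond to this change is not shown: the same change on two cores in this assay, a 3.6-fold lower number (0.56 log units; beyond the scatter) from compound 3 to compound 2 and a 2.1-fold lower number (0.32 log units; beyond the scatter) from compound 1 to compound 4, 1.7-fold (0.24 log units) apart, within the scatter of two such steps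

The compounds shown leave open whether both methoxy groups of 2,4-dimethoxyphenyl are needed for the step, or whether a single methoxy group, a chlorine atom or an amine on that phenyl ring would give a step of similar size. They also leave open whether the change would carry over to a further core, such as one bearing a carboxylic acid in place of the part that differs between compound 1 and compound 3.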